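The compounds below may be only part of what the source reports. "The series", "measured", "known", "first", "only" and "open" are said of these compounds alone.

Working notes on the series. Compound 1 `COc1cccc(NC2=CC(=O)c3c(nc4n3[C@H]3OC[C@@H](O)[C@H]3OC4)C2=O)c1` and compound 2 `COc1cccc(NC2=CC(=O)c3nc4n(c3C2=O)[C@H]2OC[C@@H](O)[C@H]2OC4)c1` share a core and the same 3-methoxyphenyl on the amine nitrogen; they differ in how that core is built up. In a functional assay on ECa-109 cells for inhibition, with ECa-109 cell line (Homo sapiens) as the target, read by sulforhodamine B assay (on this read-out higher numbers stand for weaker inhibition and lower numbers for stronger inhibition), compound 1 gives 3340 nM. In this assay, among the measured compounds shown here, compound 2 gives 7620 nM, the highest of the two numbers measured so far, and the gap to compound 1 lies beyond the usual scatter, so compound 2 is the weaker inhibitor of the pair on this read-out. For the measured compounds named here, no pair that differs in a single place has been measured, so there is no step against which a new change can be set.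

Compound 3 `CCOc1ccc(NC2=CC(=O)c3nc4n(c3C2=O)[C@H]2OC[C@@H](O)[C@H]2OC4)cc1` keeps the core of compound 2 and changes only the group on the amine nitrogen: 4-ethoxyphenyl in place of 3-methoxyphenyl on an amine nitrogen. Nothing in the measured pair speaks to this change, and the two compounds measured differ elsewhere, so no direction can be read from them. The step from compound 2 to compound 3 is expected to be small, most likely within the scatter, with a 1.1-fold lower number from compound 2 to compound 3 (0.04 log units; within the scatter) as the estimated size and no firm direction. Compound 3 is thus expected to give about 7000 nM in this assay, with a range of 2500 nM to 20000 nM.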

Compound 3, half-maximal inhibitory concentration: 3210 nM
The estimate for compound 3 lay 2.2-fold (0.34 log units) above the measured number; low and high end bracket the measured number.
By their numbers in this assay, from the lowest: compounds 3 and 1 (each within the scatter of the next); then compound 2.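

In this assay, among the compounds shown here, the change to 4-ethoxyphenyl in place of 3-methoxyphenyl on an amine nitrogen gives a 2.4-fold lower number from compound 2 to compound 3 (0.38 log units; beyond the scatter) and so supplies the first step that differs in one place, showing that the read-out responds modestly to the group at this position. The change alters both the numbering in the group's name and the ether chain, from methoxy to ethoxy, so this single step cannot assign the lower number to either alteration. No measured finding on hand accounts for the step.

As far as these compounds go, whether 4-methoxyphenyl or 3-ethoxyphenyl would separate those two alterations remains open, as does the response at this position to a longer chain such as 4-butoxyphenyl, to an amine such as 4-dimethylaminophenyl, or to a carboxylic acid on the phenyl ring. Also open is whether the step carries over to the core of compound 1, which is shown here only with the 3-methoxyphenyl group.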